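The source may hold more compounds than are shown below. What is called first, only, known or untested is meant among the compounds shown, and "the series" means these compounds.

Measured compounds in a functional assay on A549 cells (Homo sapiens) for antiproliferative activity, read by MTT assay, with a stated time of 72 h; a lower number here means a stronger inhibitor, a higher number a weaker inhibitor:
compound 1 `CCNC(=O)c1cc(Oc2ccc(NC(=O)c3nn(-c4ccccc4OC(F)(F)F)c(=O)cc3C)cc2)ccn1` gives 5280 nM
compound 2 `CCNC(=O)c1cc(Oc2ccc(NC(=O)c3nn(-c4ccccc4C)c(=O)cc3C)cc2)ccn1` gives 34800 nM
compound 3 `CCCNC(=O)c1cc(Oc2ccc(NC(=O)c3nn(-c4ccccc4C)c(=O)cc3C)cc2F)ccn1` gives 25700 nM

Compound 2 and compound 1 differ in one place: trifluoromethoxy in place of methyl on an aromatic carbon. This change gave a 6.6-fold lower number from compound 2 to compound 1 (0.82 log units; beyond the scatter) in this assay. Compound 3 and compound 2 share the same 2-methylphenyl group but have different cores; the difference between the two cores is not broken down here. Their two values lie within the usual scatter of each other, so nothing is said about order between them.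

Compound 4 `CCCNC(=O)c1cc(Oc2ccc(NC(=O)c3nn(-c4ccccc4OC(F)(F)F)c(=O)cc3C)cc2F)ccn1` is not yet measured. It stands to compound 3 as compound 1 stands to compound 2: trifluoromethoxy in place of methyl on an aromatic carbon. The place lines of both changes read the same word for word, so it is the same change made on a second core. Within the data shown here, with only one earlier instance of the change, the expectation rests on that single step and on the value of compound 3. The step in this assay is expected to be a 6.6-fold lower number from compound 3 to compound 4 (0.82 log units; beyond the scatter), about the size seen from compound 2 to compound 1. Compound 4 is therefore estimated at 3900 nM, with a range from 1500 nM to 10000 nM.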

Compound 4, half-maximal inhibitory concentration: 4220 nM
For compound 4 the middle estimate is 1.1-fold (0.03 log units) below the measured one, within the range that was stated.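

In this assay, replacing 2-methylphenyl with 2-(trifluoromethoxy)phenyl on the core of compound 3 gave a 6.1-fold lower number from compound 3 to compound 4 (0.78 log units; beyond the scatter). The step carried over to the second core with no difference in size beyond the scatter: the same change on two cores in this assay, a 6.6-fold lower number (0.82 log units; beyond the scatter) from compound 2 to compound 1 and a 6.1-fold lower number (0.78 log units; beyond the scatter) from compound 3 to compound 4, 1.1-fold (0.03 log units) apart, within the scatter of two such steps
Among these compounds, this rests on only two matched pairs, so it does not show that the step would hold on a further core, and it gives no reason for the lower number or any indication of what the change does outside this assay.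

Still open, from the compounds shown here alone, is how other groups on the same aromatic carbon, such as methoxy, chlorine or trifluoromethyl, would compare with methyl and trifluoromethoxy. Going by these compounds, the separate contributions of the differences between the cores of compound 2 and compound 3 are also open, as is the effect of replacing the ethyl or propyl chain on the amide with a longer chain or one ending in an amine or a carboxylic acid.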